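From 2-fluorophenyl to 3-fluorophenyl on a shared core

The source may hold more compounds than are shown below. What is called first, only, known or untested is meant among the compounds shown, and "the series" means these compounds.

In a functional assay on A2780 cells (Homo sapiens) for antiproliferative activity, read by resazurin assay, with a stated time of 72 h (on this read-out higher numbers stand for weaker inhibition and lower numbers for stronger inhibition), the record for this series is still thin. Compound 1 (`NC(=O)c1cc2c(Cc3ccccc3)n[nH]c2cc1O`) carries the entry "not determined" (no result reported) and so offers no number to compare. Compound 2 (`CN(Cc1ccccc1F)C(=O)c1cc2c(Cc3ccccc3)n[nH]c2cc1O`) gives 1500 nM and this is the only figure available, which means it cannot yet be ranked against any other compound.

Compound 3 (`CN(Cc1cccc(F)c1)C(=O)c1cc2c(Cc3ccccc3)n[nH]c2cc1O`) differs from compound 2 in one place, with 3-fluorophenyl in place of 2-fluorophenyl on a saturated chain carbon bound to an amide-type nitrogen. For the measured compounds named here, no step between measured compounds shows how such a change behaves in this assay and the data favour neither direction. The expectation is therefore no shift beyond the usual scatter, with compound 2 at 1500 nM as the sole anchor. The estimated change (a 1.2-fold lower number from compound 2 to compound 3 (0.06 log units; within the scatter)) is accordingly small and carries no firm direction. For compound 3 the expected value is 1300 nM with an estimated range from 400 nM to 4000 nM as the likely span of a measurement.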

Compound 3, half-maximal inhibitory concentration: 5000 nM
Compound 3: middle estimate off by 3.8-fold (0.59 log units), on the low side; measured number above the stated range.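

In this assay, for the compounds shown here, the exchange of 2-fluorophenyl for 3-fluorophenyl on a saturated chain carbon bound to an amide-type nitrogen gives a 3.3-fold higher number from compound 2 to compound 3 (0.52 log units; beyond the scatter) and so provides the first readable step. The step is modest, but it shows that this position responds to a change in which the same atoms are only joined differently, with the heavy-atom count, the aromatic ring and the absence of net charge all unchanged; of this pair, the 2-fluorobenzyl form has the lower number and thus the stronger inhibition. Nothing available here accounts for the difference.

The two compounds compared cannot show whether the trend would continue to a 4-fluorobenzyl group, or how either form would compare with a plain benzyl group, which would reveal whether the fluorine helps at one place or hurts at the other. On these data alone, it also remains open whether a 2-chlorobenzyl or 3-chlorobenzyl group would follow the same order, and whether that order would hold if the methyl on the amide nitrogen gave way to an ethyl group.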